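Removing the Methoxy Group from Compound 2

The source may hold more compounds than are shown below. What is called first, only, known or untested is meant among the compounds shown, and "the series" means these compounds.

Measured compounds:
compound 1, `N#Cc1c(-c2ccco2)nc2c(c(-c3ccccc3)nn2-c2ccccc2)c1-c1ccc(O)cc1`: 13800 nM
compound 2, `COc1cc(-c2c(C#N)c(-c3cccs3)nc3c2c(-c2ccccc2)nn3-c2ccccc2)ccc1O`: 44200 nM

Of the compounds shown here, two have so far been tested in a functional assay on MV4-11 cells (Homo sapiens) for antiproliferative activity, read by resazurin assay, with a stated time of 72 h; a lower number here means a stronger inhibitor, a higher number a weaker inhibitor. Compound 1 gives 13800 nM. Compound 2 gives 44200 nM, the higher of the two numbers; the nearest number is that of compound 1, and the gap between them lies beyond the usual scatter, so compound 2 is the weaker inhibitor of the pair. The two compounds differ in more than one place, so their values show no more than that.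

Compound 3 `N#Cc1c(-c2cccs2)nc2c(c(-c3ccccc3)nn2-c2ccccc2)c1-c1ccc(O)cc1` arises from compound 2 by hydrogen in place of methoxy on an aromatic carbon, ortho to a hydroxy group. For the measured compounds named here, no step between measured compounds shows what this change alone does. Compound 3 differs from compound 1 elsewhere only in one ring, and compound 1 gives 13800 nM, so a value near that is expected for compound 3. The step from compound 2 is expected as a 2.9-fold lower number from compound 2 to compound 3 (0.47 log units; beyond the scatter), a decrease beyond the scatter. Compound 3 is estimated at 15000 nM, within 5000 nM to 45000 nM.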

Compound 3, half-maximal inhibitory concentration: 34200 nM
Beside the measured number, compound 3's estimate is 2.3-fold (0.36 log units) below it, and the stated range covers the measured number.
By their numbers in this assay, from the lowest: compound 1; then compounds 3 and 2 (each within the scatter of the next).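

In this assay, exchanging 4-hydroxy-3-methoxyphenyl for 4-hydroxyphenyl produces no change that can be told from the scatter (a 1.3-fold lower number from compound 2 to compound 3 (0.11 log units; within the scatter)), so the methoxy group on this aromatic carbon shows no measurable effect in this pair. With 4-hydroxyphenyl held constant, the other one-place change does exceed the scatter, though only modestly: thiophen-2-yl in place of furan-2-yl gives a 2.5-fold higher number from compound 1 to compound 3 (0.39 log units; beyond the scatter) as the step. Nothing measured here explains either step.

From the compounds shown here alone, it remains open whether an amine, a fluorine atom or an ethoxy group on this aromatic carbon would move the number beyond the scatter. Going by these compounds, it is also open whether methoxy would show the same small step in a compound carrying furan-2-yl.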